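Thiourea in Place of Cyanoguanidine on a Pyridazinone Chain

The source may report more compounds than this note shows. Statements on the series, on what has been measured and on what is new or still open speak of the compounds shown alone.

Measured compounds:
compound 1, `C/N=C(/NC#N)NCCCn1nc(-c2ccccc2)ccc1=O`, in a functional assay on the whole organism (stomach) with Rattus norvegicus as the target (a higher number here means that more compound is needed for the effect, a lower number that less compound is needed), gives > 100 mg/kg, which is a limit of the assay and not a number.
compound 2, `CCC/N=C(/NC#N)NCCCCn1nc(-c2ccccc2)ccc1=O`, in this assay gives > 100 mg/kg, again a limit of the assay.

Among the measured compounds shown here, compound 1 therefore stands at the limit of > 100 mg/kg in this assay, at which 2 of the 2 values shown sit, and no step between measured compounds can be drawn from these two values. Compound 3, `CC/N=C(\S)NCCCn1nc(-c2ccccc2)ccc1=O`, differs from compound 1 by a group of 5 heavy atoms (3 carbon, 1 nitrogen, 1 sulfur; no ring) in place of a group of 6 heavy atoms (3 carbon, 3 nitrogen; no ring), on an amine nitrogen. For the measured compounds named here, because compound 1 sits only at the limit of > 100 mg/kg in this assay, at which 2 of the 2 values shown sit, no measured step guides the expectation, and the step of a number no higher from compound 1 to compound 3 (the limit leaves the size open) is expected to be none beyond the scatter. Compound 3 is expected to give 100 mg/kg in this assay, within 30 mg/kg to 300 mg/kg, most likely again reported as a limit.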

Compound 3, dose for half-maximal effect: > 100 mg/kg
Compound 3 ended at the assay's limit; the forecaster's own chance of this, stated with the estimate: 70%; the middle value sits exactly at the limit.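

Compound 3 sits at a limit of this assay, as compound 1 does, so no step can be read between these two compounds: the limit of > 100 mg/kg in this assay, at which 3 of the 3 values shown sit. The compounds shown leave open whether the group on the amine nitrogen changes the dose needed at all.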